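Replacing the 3-carboxypropoxy chain on compound 2

The source may hold more compounds than are shown below. What is called first, only, known or untested is meant among the compounds shown, and "the series" means these compounds.

In an ADME assay on S9 fraction from liver (Mus musculus, strain CD-1) for metabolic stability, read by LC-MS, using NADPH, with stated times of 5 min and 60 min, tested at 5 uM (a higher number here means that more of the compound is left, a lower number that less of the compound is left), compound 2 (`COc1cc(C2CN(C(=O)c3cc(OCCCC(=O)O)ccn3)C2)ccc1OCc1ccc(C2CC2)cc1`) gives 88% and stands highest of the three measured numbers, beyond the scatter from both others. It is the only one of the three with a 3-carboxypropoxy group: compound 1 (`COc1ccc(COc2ccc(C3CN(C(=O)c4cc(OCCO)ccn4)C3)cc2OC)cc1`) gives 48% and compound 3 (`CCc1ccc(COc2ccc(C3CN(C(=O)c4cc(COC[C@@H](O)CO)ccn4)C3)cc2OC)cc1`) gives 26% without it. Compound 4 (`COc1cc(C2CN(C(=O)c3cc(COCC(CO)(CO)CO)ccn3)C2)ccc1OCc1ccc(C2CC2)cc1`) has (3-hydroxy-2,2-bis(hydroxymethyl)propoxy)methyl in place of 3-carboxypropoxy on an aromatic carbon. Going by the values given here, no measured pair shows this change alone, so the expectation is uncertain. The expected result is a fall beyond the scatter, estimated as a number 43 percentage points lower from compound 2 to compound 4 (beyond the scatter) in this assay for now. Compound 4 is expected to give 45% within an estimated range from 20% to 75% of compound remaining.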

Compound 4, percent of the compound remaining: 81%
The estimate for compound 4 lay 36 percentage points below the measured number, outside the stated range (above it).
By their numbers in this assay, from the lowest: compound 3; then compound 1; then compounds 4 and 2 (each within the scatter of the next).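

In this assay, replacing the chain on this aromatic carbon, opposite the ring nitrogen, gives a number 7 percentage points lower from compound 2 to compound 4 (within the scatter). Going by these compounds alone, this is the first comparison here in which only one place differs, and it shows that the high number of compound 2 does not depend on keeping 3-carboxypropoxy, since (3-hydroxy-2,2-bis(hydroxymethyl)propoxy)methyl serves equally well on this core. Nothing available explains why the two groups cannot be told apart. Still open, on these data alone, is how an amine at this place would fare in this assay, and whether the same swap would hold on a different core.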